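The compounds below may be only part of what the source reports. "The series", "measured", "known", "first", "only" and "open" are said of these compounds alone.

Measured in a functional assay (trachea) with Cavia porcellus as the target; a lower number here means that less compound is needed, a higher number that more compound is needed for the effect:
- compound 1 `C=CCCn1cnc2c1c(=O)n(C)c(=O)n2CCC`: 16800 nM
- compound 2 `CCCn1c(=O)n(C)c(=O)c2c1ncn2CCC(=O)O`: > 100000 nM (a limit, not a number)
- compound 3 `CCCn1c(=O)n(C)c(=O)c2c1ncn2CCC#N`: 27600 nM

Compound 3 gives 27600 nM, and the comparison with its nearest neighbour is a 1.6-fold higher number from compound 1 to compound 3 (0.22 log units; within the scatter). These two values therefore cannot be told apart. Compound 2 has only a limit, > 100000 nM.

The next change leads to compound 4 `CCCn1c(=O)n(C)c(=O)c2c1ncn2CCC(C)=O`, with acetyl in place of cyano on a saturated chain carbon, two bonds along the chain from an aromatic nitrogen. All three measured steps lie at this same place. Exchanging vinyl for cyano gave a 1.6-fold higher number from compound 1 to compound 3 (0.22 log units; within the scatter). Among the compounds with values here, only the steps involving carboxy go beyond the scatter, with an at least 5.9-fold higher number from compound 1 to compound 2 (0.77 log units; beyond the scatter) and an at least 3.6-fold lower number from compound 2 to compound 3 (0.55 log units; beyond the scatter). Compound 2 thus stands apart from the other two, though both of its steps rest on a limit.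

Acetyl has not been tested at this place, so the expectation rests on the closest precedent, a 1.6-fold higher number from compound 1 to compound 3 (0.22 log units; within the scatter), and on the absence of net charge in both acetyl and cyano. In this assay, the expected step is a 1.1-fold higher number from compound 3 to compound 4 (0.04 log units; within the scatter), which means no expected change beyond the scatter. The estimate for compound 4 is 30000 nM, with an expected range from 12000 nM to 80000 nM.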

Compound 4, half-maximal effective concentration: 12200 nM
For compound 4 the middle estimate is 2.5-fold (0.39 log units) above the measured one; the range from low to high includes it.
By their numbers in this assay, from the lowest: compounds 4, 1 and 3 (each within the scatter of the next, the first and the last beyond it). At a limit, above all of these: compound 2.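

Within the data shown here, at this place, on a saturated chain carbon, two bonds along the chain from an aromatic nitrogen, acetyl in place of cyano gives the first step in this assay that goes beyond the scatter without involving carboxy, though it remains modest (a 2.3-fold lower number from compound 3 to compound 4 (0.35 log units; beyond the scatter)). Acetyl and vinyl cannot be told apart (a 1.4-fold lower number from compound 1 to compound 4 (0.14 log units; within the scatter)), and the same holds for vinyl and cyano, so among these three groups only acetyl and cyano separate, with vinyl falling within the scatter of both. Compound 2 remains at a limit rather than a number, so methyl in place of hydroxy on a carbonyl carbon gives only a bound on the step (an at least 8.1-fold lower number from compound 2 to compound 4 (0.91 log units; beyond the scatter)), and its true size cannot be read: the limit of > 100000 nM in this assay, at which 1 of the 4 values shown sits.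

On these data alone, it remains open whether a methyl ester or a primary amide at this place would read like acetyl or like carboxy, and whether a longer chain between the aromatic nitrogen and the carbonyl would preserve the number seen for compound 4. All four compounds share one core, so they do not show whether the step from cyano to acetyl would carry over to a different core.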